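The source may hold more compounds than are shown below. What is called first, only, known or untested is meant among the compounds shown, and "the series" means these compounds.

Measured so far:
compound 1, `O=C1O/C(=C\c2cc(Br)c(O)c(Br)c2)C(c2ccc(O)c(Br)c2)=C1C(=O)c1cc(Br)c(O)c(Br)c1`: > 100000 nM
compound 2, `COC(=O)C(C(=O)c1cc(Br)c(O)c(Br)c1)=C(C(=O)OC)c1cc(Br)c(O)c(Br)c1`: 53700 nM

In an ADME assay on K562 cells (Homo sapiens) for cytotoxicity, read by MTT assay, with a stated time of 48 h (on this read-out lower numbers stand for higher toxicity in this test and higher numbers for lower toxicity in this test), compound 2 gives 53700 nM, the only number among the two results shown. In this assay compound 1 gives > 100000 nM, which is a limit of the assay and not a number; this is the limit of > 100000 nM in this assay, at which 1 of the 2 values shown sits. Among the measured compounds shown here, no step between measured compounds is available, so nothing yet tells how a single change moves the read-out.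

Compound 3, `COC(=O)C(C(=O)c1cc(Br)c(O)c(Br)c1)=C(C(=O)OC)c1ccc(O)c(Br)c1`, differs from compound 2 in one place: hydrogen in place of bromo on an aromatic carbon. One bromine of one heavy atom leaves and a hydrogen enters on an aromatic carbon. With compound 2 as the only numbered anchor, the step from compound 2 to compound 3 in this assay is expected to be small, within or just beyond the scatter, and if anything toward a higher number. Compound 3 is therefore estimated at 70000 nM, with a range from 30000 nM to 150000 nM, an expected step of a 1.3-fold higher number from compound 2 to compound 3 (0.12 log units; within the scatter).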

Compound 3, concentration lethal to 50% of the cells: 49700 nM
Compound 3: middle estimate off by 1.4-fold (0.15 log units), on the high side, and the stated range covers the measured number.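

In this assay, the series now has its first readable step, a 1.1-fold lower number from compound 2 to compound 3 (0.03 log units; within the scatter), where a 3,5-dibromo-4-hydroxyphenyl group becomes 3-bromo-4-hydroxyphenyl. Losing this bromo group, ortho to a hydroxy group, therefore leaves the read-out within the scatter, so for this pair the group makes no measurable difference to the toxicity seen in this test. Compound 1 remains a limit of the assay and enters no step: the limit of > 100000 nM in this assay, at which 1 of the 3 values shown sits.

The compounds shown leave open whether the same holds for the remaining bromo group on this ring, or for the bromo groups on the other 3,5-dibromo-4-hydroxyphenyl group. They also do not show what an amine or a methoxy group would do at this position, or what a carboxylic acid would do in place of the methyl esters.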